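Benzyloxy in Place of Methyl: An Expected Potency Value

The compounds below may be only part of what the source reports. "The series", "measured", "known", "first", "only" and "open" are said of these compounds alone.

Compound 1 `CCc1nc(N)nc(N)c1-c1ccc(NCc2cc(F)c(S(C)(=O)=O)c(F)c2)cc1`: 45 nM
Compound 2 `CCc1nc(N)nc(N)c1-c1ccc(NCc2cc(F)c(S(=O)(=O)C(F)(F)F)c(F)c2)cc1`: 690 nM

In a functional assay on CHOK cells for antagonist activity at growth hormone secretagogue receptor type 1 (Homo sapiens), read by calcium flux (on this read-out lower numbers stand for stronger inhibition and higher numbers for weaker inhibition), compound 1 gives 45 nM and compound 2 gives 690 nM. Compound 2 stands highest of the two numbers. Among the measured compounds shown here, the single measured step, a 15-fold higher number from compound 1 to compound 2 (1.19 log units; beyond the scatter), arises from trifluoromethyl in place of methyl on a sulfonyl sulfur.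

Compound 3 `Nc1nc(N)c(-c2ccc(NCc3cc(F)c(S(=O)(=O)C(F)(F)F)c(F)c3)cc2)c(COCc2ccccc2)n1` differs from compound 2 by benzyloxy in place of methyl on a saturated chain carbon bound to an aromatic carbon; cut one bond further out, the same difference reads ethyl to (benzyloxy)methyl. For the measured compounds named here, no measured step touches this part of the molecule, so nothing in hand predicts its size or direction. Lacking a comparable step, compound 3 is expected to move by a 1.0-fold higher number from compound 2 to compound 3 (0.01 log units; within the scatter). Compound 3 is therefore estimated at 700 nM, with a range from 150 nM to 3000 nM.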

Compound 3, half-maximal inhibitory concentration: 85 nM
Compound 3: middle estimate off by 8.2-fold (0.92 log units), on the high side; measured number outside the range, below it.
By their numbers in this assay, from the lowest: compounds 1 and 3 (each within the scatter of the next); then compound 2.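

This position was untouched by the earlier step, and it clearly matters: changing ethyl to (benzyloxy)methyl gives an 8.1-fold lower number from compound 2 to compound 3 (0.91 log units; beyond the scatter), which here means stronger inhibition. The position therefore accepts a much larger group, one with a six-membered aromatic ring, at least in a compound carrying trifluoromethyl on the sulfonyl sulfur. Nothing available explains this gain.

Going by these compounds, whether the oxygen or the aromatic ring matters more remains open, as does the effect of an amine or a longer chain here. It is also unknown whether (benzyloxy)methyl would help when the sulfonyl sulfur carries methyl, as in compound 1.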